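The compounds below may be only part of what the source reports. "The series", "measured", "known", "first", "only" and "open" are said of these compounds alone.

Compound 3 `CN1CCC(n2nnc3c2CCC(c2nc(-c4ccc(F)cc4)no2)C3)CC1` carries a 1-methylpiperidin-4-yl group on the aromatic nitrogen of its fused core. In a functional assay on U2OS cells for positive allosteric modulation of metabotropic glutamate receptor 5 (Homo sapiens), read by calcium flux, in the presence of a further agent that is not named here (a higher number here means that more compound is needed for the effect, a lower number that less compound is needed), compound 3 gives 3980 nM, the highest of the two single numbers shown. The nearest comparison is compound 1 `Fc1ccc(-c2nc(-c3ccc4c(c3)nnn4C3CCCC3)no2)cc1`, which in this assay gives 398 nM, a difference beyond the scatter. In this assay compound 2 `Fc1ccc(-c2noc(C3CCc4c(nnn4C4CCCC4)C3)n2)cc1`, bearing a cyclopentyl group on its core, gives 398 nM; 31.6 nM (2 entries); as several entries, (the several entries of compound 2 in this assay, 398 nM; 31.6 nM (2 entries)), these offer no single number to rank against.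

Compound 4 `CC(C)n1nnc2c1CCC(c1nc(-c3ccc(F)cc3)no1)C2` has not yet been measured. It differs from compound 3 in one place: isopropyl in place of 1-methylpiperidin-4-yl on an aromatic nitrogen. Going by the values given here, no measured pair isolates this exact change, so the expectation rests on compound 3 at 3980 nM and on compound 2, whose entries the several entries of compound 2 in this assay, 398 nM; 31.6 nM (2 entries) sit lower with a hydrocarbon group on the core. The step of a 10-fold lower number from compound 3 to compound 4 (1.00 log units; beyond the scatter) is expected to lower the number beyond the scatter. Compound 4 is therefore estimated at 400 nM, with a range from 60 nM to 2000 nM.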

Compound 4, half-maximal effective concentration: 398 nM
Beside the measured number, compound 4's estimate is 1.0-fold (0.00 log units) above it; the range from low to high includes it.
By their numbers in this assay, from the lowest: compounds 1 and 4 (each within the scatter of the next); then compound 3.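

Going by these compounds alone, the new pair is the first to isolate a change at this position, on an aromatic nitrogen of the shared core, and it shows that the number in this assay depends on the group placed there: isopropyl in place of 1-methylpiperidin-4-yl gives a 10-fold lower number from compound 3 to compound 4 (1.00 log units; beyond the scatter). The earlier compounds shown here could not show this, since no measured pair differed only in this group. Compound 2 carries cyclopentyl at the same place, but it offers no single number to set against compound 4: the several entries of compound 2 in this assay, 398 nM; 31.6 nM (2 entries).

The step removes the ring and its nitrogen together, so the compounds shown do not tell which of the two accounts for the difference. A cyclohexyl group, which keeps the ring without the nitrogen, or an open-chain tertiary amine, which keeps the nitrogen without the ring, would separate the two.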